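The source may report more compounds than this note shows. Statements on the series, on what has been measured and on what is new or still open speak of the compounds shown alone.

Measured in a functional assay on MCF7 cells (Homo sapiens) for antiproliferative activity, read by MTT assay; a lower number here means a stronger inhibitor, a higher number a weaker inhibitor:
- compound 1 `CC(=O)c1ccc(-n2cc(COc3ccc(/C=C/C(=O)c4cc5c(cc4O)OC(C)(C)CC5)cc3)nn2)cc1`: 182000 nM
- compound 2 `CCc1ccccc1-n1cc(COc2ccc(/C=C/C(=O)c3cc4c(cc3O)OC(C)(C)CC4)cc2)nn1`: "not active" (no number reported)

Compound 2 has no single number to place it on the scale. In this assay compound 2 is reported only as "not active" (no number reported), so the one numerical reference in the series is compound 1 at 182000 nM. The two compounds therefore cannot be separated by a measured step.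

The next compound for testing is compound 3 `CCCCCCCCn1cc(COc2ccc(/C=C/C(=O)c3cc4c(cc3O)OC(C)(C)CC4)cc2)nn1`, which has not yet been measured. The structural change is octyl in place of 2-ethylphenyl on an aromatic nitrogen. Among the measured compounds shown here, no measured step shows what such a swap does, so the expectation is only tentative. A modest step towards stronger inhibition in this assay is expected, from no reported number to a measurable but weak value, near the level of compound 1 at 182000 nM. A result with no number again remains a real possibility. For compound 3 the estimated value is 80000 nM, with an expected range of 15000 nM to 250000 nM.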

Compound 3, half-maximal inhibitory concentration: "not active" (no number reported)
No number was reported for compound 3; no gap can be computed for the estimate.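

In this assay compound 2 and compound 3 are both reported only as "not active", with no number, so no step can be read for octyl in place of 2-ethylphenyl. No measured evidence bears on this result. Whether these two groups differ at all in this assay remains open in the compounds shown.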